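A Thiophene in Place of an Ethoxyphenyl on the Core

The source may report more compounds than this note shows. Statements on the series, on what has been measured and on what is new or still open speak of the compounds shown alone.

Compound 1 `C=C(Br)C(=O)Nc1cccc(-c2cn3nc(-c4ccc(OCC)cc4)sc3n2)c1` was tested in a functional assay on FM3A cells (Mus musculus) for inhibition, read by cell counting, with a stated time of 2 days (a lower number here means a stronger inhibitor, a higher number a weaker inhibitor), where compound 1 gives 1100 nM. Among the measured compounds shown here, of the two numbers known, that is the lower one; the only comparison, compound 2 `COc1ccc(-c2csc3nc(-c4cccc(N)c4)cn23)cc1`, gives 11000 nM in this assay, and the gap between the two lies beyond the scatter. For the measured compounds named here, compound 2 differs from compound 1 in more than one place, so the two values alone set the frame and no single-change step is available.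

Compound 3 `C=C(Br)C(=O)Nc1cccc(-c2cn3nc(-c4cccs4)sc3n2)c1` has not been measured. It differs from compound 1 in one place: thiophen-2-yl in place of 4-ethoxyphenyl on an aromatic carbon. Going by the values given here, no measured pair shows what this change does on the shared core, so in this assay only a modest step is expected, if any, more likely toward a somewhat higher number than a lower one. Compound 3 is expected to give about 2000 nM, within a range from 600 nM to 7000 nM. This estimate means a step of a 1.8-fold higher number from compound 1 to compound 3 (0.26 log units; within the scatter).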

Compound 3, half-maximal inhibitory concentration: 370 nM
Estimate against measurement, compound 3: 5.4-fold (0.73 log units) above; measured number outside the range, below it.
By their numbers in this assay, from the lowest: compound 3; then compound 1; then compound 2.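

Among the compounds shown here, the step of a 3.0-fold lower number from compound 1 to compound 3 (0.47 log units; beyond the scatter) is the first single-change comparison on the shared core, and it shows that in this assay this position does not depend on the 4-ethoxyphenyl group. Thiophen-2-yl, with fewer heavy atoms and a five-membered aromatic ring in place of a six-membered one, gives a lower number by a margin beyond the scatter, so the position responds to what it carries. Nothing shown here says which feature of the exchange accounts for this.

On these data alone, a single step cannot separate the change of ring from the loss of the ethoxy group, so it remains open how a plain phenyl or a thiophen-3-yl would compare at this position. As far as these compounds go, it is also open whether a small group such as methyl or an amine on this carbon would keep the lower number.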